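Pyrazolyl acetamide on the thiazole-piperazine core: an expectation

The compounds below may be only part of what the source reports. "The series", "measured", "known", "first", "only" and "open" are said of these compounds alone.

Measured compounds:
compound 1, `Cc1ncc(-c2nc(C(F)(F)F)sc2N2CCN(C(=O)Cn3cnc4cccnc43)[C@H](C)C2)cn1` — 168 nM
compound 2, `CCOc1ncc(-c2nc(C(F)(F)F)sc2N2CCN(C(=O)Cn3ccc4cccnc43)[C@H](C)C2)cn1` — 47 nM

In a functional assay on U2OS cells for antagonist activity at C-X-C chemokine receptor type 3 (Homo sapiens), read by beta-arrestin recruitment (a lower number here means a stronger inhibitor, a higher number a weaker inhibitor), compound 2 gives 47 nM, and in the same assay compound 1 gives 168 nM. Of the two numbers, compound 2 holds the lower one, and the gap between compound 2 and compound 1 lies beyond the usual scatter. Among the measured compounds shown here, compound 1 and compound 2 differ in more than one place, so the two values show only that compound 2 is the stronger of the pair, not which of its parts carries the difference.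

Compound 3, `CCOc1ncc(-c2nc(C(F)(F)F)sc2N2CCN(C(=O)Cn3nc(C)cc3C)[C@H](C)C2)cn1`, has not yet been measured in this assay. It differs from compound 2 in one place: a group of 7 heavy atoms (5 carbon, 2 nitrogen; one five-membered aromatic ring with 2 hetero atoms) in place of a group of 9 heavy atoms (7 carbon, 2 nitrogen; one five-membered aromatic ring with 1 hetero atom, one six-membered aromatic ring with 1 hetero atom), on a saturated chain carbon bound to a carbonyl carbon. The 3,5-dimethyl-1H-pyrazol-1-yl group sits on a saturated chain carbon bound to a carbonyl carbon, where compound 2 carries a larger two-ring group. For the measured compounds named here, no measured pair shows a change of this kind, so the expectation rests on compound 2 alone.

The step is expected to be a 2.6-fold higher number from compound 2 to compound 3 (0.41 log units; beyond the scatter), which would be a moderate rise in the number. Compound 3 is therefore estimated at 120 nM, with a likely range from 40 nM to 400 nM.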

Compound 3, half-maximal inhibitory concentration: 87 nM
Estimate against measurement, compound 3: 1.4-fold (0.14 log units) above; the range from low to high includes it.
By their numbers in this assay, from the lowest: compounds 2, 3 and 1 (each within the scatter of the next, the first and the last beyond it).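

Among the compounds shown here, compound 3 gives the first reading of a change at this position, the saturated chain carbon bound to a carbonyl carbon. In this assay, replacing the two-ring group with 3,5-dimethyl-1H-pyrazol-1-yl gives a 1.9-fold higher number from compound 2 to compound 3 (0.27 log units; within the scatter). The second ring is therefore not required to keep the number within the scatter of compound 2, at least with this pair, and a single five-membered aromatic ring with 2 hetero atoms serves at this place, with fewer heavy atoms and the same counts of hydrogen-bond donors and acceptors as the group it replaces. No measurement shown here accounts for this result, so the reason for it remains unknown.

What an unsubstituted 1H-pyrazol-1-yl group, which would show whether the two methyl groups contribute, or a dimethylamino group would give at this place remains an open question. Compound 1 differs from both compound 2 and compound 3 in more than one place, so the compounds shown also leave open how much of its number comes from its group on the chain carbon and how much from the other difference.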